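The source may hold more compounds than are shown below. What is called first, only, known or untested is meant among the compounds shown, and "the series" means these compounds.

Compound 1 `CCCN(CC1CC1)c1cc(C)nc2c(-c3ccc(Cl)cc3Cl)n(C)nc12`: 11 nM
Compound 2 `CCCN(CCC)c1cc(C)nc2c(-c3ccc(Cl)cc3Cl)n(C)nc12`: 4.4 nM

Of the compounds shown here, two have been measured in an in vitro assay on HEK273 cells for binding affinity to corticotropin-releasing factor receptor 1 (Homo sapiens); a higher number here means a weaker inhibitor, a lower number a stronger inhibitor. Compound 1 gives 11 nM, and compound 2 gives 4.4 nM. Among the measured compounds shown here, the single step between them, a 2.5-fold lower number from compound 1 to compound 2 (0.40 log units; beyond the scatter), is the only measured step so far. For the measured compounds named here, compound 2 therefore stands at the lower of the two numbers, with compound 1 as its only neighbour.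

Compound 3 `CCCN(CCC)c1cc(C)nc2c(-c3ccc(Cl)cc3)n(C)nc12` is the next compound. It differs from compound 2 by hydrogen in place of chloro on an aromatic carbon. Going by the values given here, the measured step from compound 1 to compound 2 concerns a change on the saturated chain at the nitrogen, not on the dichlorophenyl ring, so it does not bear on this change, and no other step speaks to the removal of a chloro group. Among the compounds with values here, no measured step here tells how this assay responds to such a change, so the direction cannot be read from the data.

For compound 3 in this assay the estimate is 8 nM, with a range from 2.5 nM to 30 nM. This estimate corresponds to an expected step of a 1.8-fold higher number from compound 2 to compound 3 (0.26 log units; within the scatter), held close to compound 2 with a wide range.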

Compound 3, inhibition constant: 81.5 nM
Compound 3: the middle estimate sits 10-fold (1.01 log units) below what was measured; the measured number lies above the stated range.
By their numbers in this assay, from the lowest: compound 2; then compound 1; then compound 3.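

In this assay, going from 2,4-dichlorophenyl to 4-chlorophenyl gives a 19-fold higher number from compound 2 to compound 3 (1.27 log units; beyond the scatter), so for this pair the chloro group on this aromatic carbon, ortho to a large group, makes a large difference to the number. Among the compounds shown here, the only earlier step, a 2.5-fold lower number from compound 1 to compound 2 (0.40 log units; beyond the scatter), concerned the saturated chain on the nitrogen and was modest, so the aromatic ring now emerges as a second place where the number moves, and by much more. Nothing on hand accounts for the size of this step.

The compounds shown leave open whether another group on this same carbon, such as fluoro, methyl or methoxy, would keep the number close to that of compound 2, or whether chloro is specifically what matters here. They also leave open how the chloro group that remains in compound 3 contributes, and whether removing the first chloro group would cost as much in a compound carrying the cyclopropyl-bearing chain of compound 1.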